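Working notes on a two-compound growth inhibition series

This account rests on a few compounds, and the source may have more. Where it says the series, first, only, none or still open, it means among the compounds named here.

compound 1 `COc1ccc(/C=C/c2cc(=O)cco2)cc1` — 328 uM
compound 2 `O=C1C=CCC(/C=C/c2ccccc2)N1` — > 1250 uM

Growth inhibition is followed in a functional assay on OVCAR-3 cells (Homo sapiens) for inhibition, read by sulforhodamine B assay, with a stated time of 48 h; a higher number here means a weaker inhibitor of growth, a lower number a stronger inhibitor of growth. Compound 1 `COc1ccc(/C=C/c2cc(=O)cco2)cc1` gives 328 uM in this assay. Compound 2 `O=C1C=CCC(/C=C/c2ccccc2)N1` is recorded in this assay only as a limit, > 1250 uM, and not as a number. That limit is the limit of > 1250 uM in this assay, at which 1 of the 2 values shown sits. Going by the values given here, compound 2 therefore stands at the weak end of the two values shown; no step between compound 1 and compound 2 is computed, and the two values show only that compound 1 has a number where compound 2 has a limit.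

Compound 3 `O=C1C=CCC(/C=C/c2ccccc2C(F)(F)F)N1` differs from compound 2 in one place: trifluoromethyl in place of hydrogen on an aromatic carbon. Among the compounds with values here, no step between measured compounds exists for this change in this assay, so no size can be read from the data, and nothing beyond the usual scatter is expected in either direction. Compound 3 is expected to give 1000 uM in this assay, with a range from 300 uM to 2500 uM. Compound 3 is thus expected to show an at least 1.2-fold lower number from compound 2 to compound 3 (0.09 log units; that floor lies within the scatter), and a limit rather than a number is the more likely outcome.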

Compound 3, concentration for growth inhibition (reported as GI): 329 uM
The estimate for compound 3 lay 3.0-fold (0.48 log units) above the measured number; the range from low to high includes it.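

In this assay, going by these compounds alone, trifluoromethyl in place of hydrogen on an aromatic carbon, ortho to a group of 9 heavy atoms, gives the first readable step: an at least 3.7-fold lower number from compound 2 to compound 3 (0.57 log units; beyond the scatter). The earlier compounds offered no step at all, so this place on the six-membered aromatic ring of carbon only is now shown to respond to substitution, and the change replaces the limit of compound 2 with a number for compound 3. The size of the step remains a floor because compound 2 is recorded only as a limit: the limit of > 1250 uM in this assay, at which 1 of the 3 values shown sits.

As far as these compounds go, it remains open whether a step of this size belongs to trifluoromethyl specifically or would also be reached with a single fluorine, a nitrile or a carboxylic acid on the same aromatic carbon. Compound 1 has no partner here that differs from it in one place, and whether the same change would give a comparable step on the core of compound 1 stays unread.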